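The source may hold more compounds than are shown below. What is called first, only, known or untested is meant among the compounds shown, and "the series" means these compounds.

Going by the values given here, in a functional assay on A-375 cells (Homo sapiens) for antiproliferative activity (a higher number here means a weaker inhibitor, a lower number a stronger inhibitor), compound 2 `O=C(Nc1ccc(-c2cscn2)cc1)C1CCCN(Cc2cccc(F)c2)C1` gives 2450 nM, the only true number so far. Compound 1 `O=C(Nc1ccc(-c2cscn2)cc1)C1CN(Cc2ccc(F)c(F)c2)C1` reads > 20000 nM, which is a limit of the assay and not a number. Compound 3 `O=C(Nc1ccc(-c2cscn2)cc1)C1CCCN(Cc2cccc(OC(F)(F)F)c2)C1` reads > 20000 nM, which is also a limit. The results so far are therefore thin, with the limit of > 20000 nM in this assay, at which 2 of the 3 values shown sit.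

The next compound, compound 4 `O=C(Nc1ccc(-c2cscn2)cc1)C1CCCN(Cc2cccnc2)C1`, differs from compound 2 in one place: pyridin-3-yl in place of 3-fluorophenyl on a saturated chain carbon bound to an amine nitrogen in a ring. In words, pyridin-3-yl stands in place of 3-fluorophenyl on a saturated chain carbon bound to an amine nitrogen in a ring. Among the compounds with values here, only one measured step touches this part of the molecule, and it is an at least 8.1-fold higher number from compound 2 to compound 3 (0.91 log units; beyond the scatter). That step swaps a substituent rather than the ring itself, so it is only a loose guide, but it does show compound 2 losing activity when this group is altered. A smaller move in the same direction seems likely, and the expected change is a 2.4-fold higher number from compound 2 to compound 4 (0.39 log units; beyond the scatter). For compound 4, the estimated value in this assay is 6000 nM, with an expected range of 2000 nM to 20000 nM.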

Compound 4, half-maximal inhibitory concentration: > 20000 nM
Compound 4 was reported as a limit (the forecaster's own chance of this, stated with the estimate: 35%); middle value at least 3.3-fold (0.52 log units) from the limit.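

Putting pyridin-3-yl in place of 3-fluorophenyl in this assay gives an at least 8.1-fold higher number from compound 2 to compound 4 (0.91 log units; beyond the scatter), so replacing the whole ring loses activity, whereas the earlier step changed only a substituent on it. Compound 4 reads > 20000 nM, which is a limit of the assay. Both changes from compound 2 at this place now lose activity, leaving the 3-fluorobenzyl compound as the only one here with a true number: the limit of > 20000 nM in this assay, at which 3 of the 4 values shown sit.

This single change removes the fluorine and brings in a ring nitrogen together, so the compounds shown cannot say which of the two matters. An unsubstituted phenyl ring would separate these two effects, and a chloro or methoxy group on the phenyl ring would show whether any substituent other than fluoro is tolerated here.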